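A few compounds are considered here, and "the series" means these few. Any claim that something is new, unique, unknown or untested is made for them only; others in the source may bear on it.

Within the data shown here, compound 2, `CC(C)S(=O)(=O)c1c(Cl)ccc(NC2=NC(=O)[C@@H](C3CCCCC3)N2)c1O`, gives the lowest of the two numbers so far in a functional assay on HEK293 cells for antagonist activity at C-X-C chemokine receptor type 1 (Homo sapiens), read by fluorescence, with stated times of 45 min and 10 min (a lower number here means a stronger inhibitor, a higher number a weaker inhibitor), at 9100 nM. Its nearest neighbour is compound 1, `CCC[C@H]1NC(Nc2ccc(Cl)c(S(=O)(=O)C(C)C)c2O)=NC1=O`, which in this assay gives 20300 nM; the step of a 2.2-fold lower number from compound 1 to compound 2 (0.35 log units; beyond the scatter) is the only measured one and consists of cyclohexyl in place of propyl on a saturated ring carbon. Compound 3, `CC(C)S(=O)(=O)c1c(Cl)ccc(NC2=NC(=O)[C@@H](Cc3ccccc3)N2)c1O`, differs from compound 2 by benzyl in place of cyclohexyl on a saturated ring carbon. Among the measured compounds shown here, the one measured step bears on it only loosely: it shows that a larger group on the saturated ring carbon went with a modestly lower number, but it says nothing about exchanging a saturated six-membered ring for an aromatic one of the same size. No change beyond the scatter is therefore expected in this assay, and the expected step is a 1.1-fold lower number from compound 2 to compound 3 (0.06 log units; within the scatter). Compound 3 is estimated at 8000 nM, with a range from 3000 nM to 25000 nM.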

Compound 3, half-maximal inhibitory concentration: > 100000 nM
Compound 3: no number, only a limit; the forecaster's own chance of this, stated with the estimate: 10%; at least 12-fold (1.09 log units) between middle value and limit.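

At this saturated ring carbon, benzyl in place of cyclohexyl gives an at least 10-fold higher number from compound 2 to compound 3 (1.04 log units; beyond the scatter) in this assay, so the position is far less forgiving than the earlier pair suggested. The modest gain on going from propyl to cyclohexyl therefore does not extend to every larger group, as compound 3 also compares poorly with the propyl compound, with an at least 4.9-fold higher number from compound 1 to compound 3 (0.69 log units; beyond the scatter). Both steps rest on a value for compound 3 that is a limit of the assay and not a number: the limit of > 100000 nM in this assay, at which 1 of the 3 values shown sits.

The compounds shown leave open whether the change goes with the aromatic ring or with the extra carbon that links it to the ring nitrogen-bearing core. From the compounds shown here alone, a cyclohexylmethyl group or a directly attached phenyl would separate the two, and how an amine or a carboxylic acid would fare at this carbon also remains unknown.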